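This account rests on a few compounds, and the source may have more. Where it says the series, first, only, none or still open, it means among the compounds named here.

For the measured compounds named here, in a functional assay on MCF7 cells (Homo sapiens) for antiproliferative activity, read by sulforhodamine B assay, with a stated time of 48 h (on this read-out lower numbers stand for stronger inhibition and higher numbers for weaker inhibition), three compounds have numbers so far. Compound 1 `COc1ccc(C2C=C(c3cc(OC)c(OC)c(OC)c3)NC(=S)N2)cc1` gives 103 nM. Compound 3 `COc1cc(C2=CC(c3ccc(F)cc3)NC(=S)N2)cc(OC)c1OC` gives 125 nM, and these two numbers lie within the usual scatter of repeat measurements. Compound 2 `COc1ccc(C2=NN(c3ccccc3)C(c3ccc(OC)cc3)C2O)cc1`, which is built differently from the other two, gives 19 nM. Going by the values given here, that number is clearly lower than the one for compound 3, so compound 3 stands on the weaker side of this small set, level with compound 1.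

The next compound, compound 4 `COc1cc(C2=CC(c3ccc(Cl)cc3)NC(=S)N2)cc(OC)c1OC`, differs from compound 3 in one place: chloro in place of fluoro on an aromatic carbon. In plain terms, this is chloro in place of fluoro on an aromatic carbon, or 4-fluorophenyl to 4-chlorophenyl. Among the compounds with values here, the only measured step that bears on this change is a 1.2-fold higher number from compound 1 to compound 3 (0.08 log units; within the scatter), where fluoro took the place of methoxy on an aromatic carbon. Exchanging that group has therefore not moved the number beyond the scatter so far. Within the data shown here, this is a single step, and no chloro compound has yet been measured, so the evidence is thin. No shift beyond the scatter is expected in this assay, and neither direction is favoured. The expected change is a 1.0-fold lower number from compound 3 to compound 4 (0.02 log units; within the scatter). Compound 4 is estimated at 120 nM, with an expected range from 55 nM to 260 nM.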

Compound 4, half-maximal inhibitory concentration: 120 nM
For compound 4 middle estimate and measured number coincide at the digits printed; low and high end bracket the measured number.
By their numbers in this assay, from the lowest: compound 2; then compounds 1, 4 and 3 (each within the scatter of the next).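

In this assay, chloro in place of fluoro at this place on the ring, para to a large group, gives a 1.0-fold lower number from compound 3 to compound 4 (0.02 log units; within the scatter) and so leaves the number level. Set beside this, chloro in place of methoxy gives a 1.2-fold higher number from compound 1 to compound 4 (0.07 log units; within the scatter), so methoxy, fluoro and chloro have now all been tried at this one position on the same shared core, and no exchange among them has moved the number beyond the scatter; the earlier compounds offered only one such exchange, while this result adds a second halogen and closes the triangle of steps among the three. No measured property of these groups accompanies the result, so the data describe this flat stretch without accounting for it.

What the compounds shown leave open is whether this position stays as tolerant with a group of another kind, such as an amine, a carboxylic acid or a longer alkyl chain. For the compounds shown here, compound 2 is built differently and is joined to the others by no single-place step, so its number says nothing about this position.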